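Fluorine on the ring of a thiomorpholine thiosemicarbazone

This account rests on a few compounds, and the source may have more. Where it says the series, first, only, none or still open, it means among the compounds named here.

Among the compounds with values here, the series is small: compound 1 `N/C(=N\NC(=S)N1CCCC1)c1ccc(F)cn1` and compound 2 `N/C(=N\NC(=S)N1CCSCC1)c1ccccn1` share a core but differ at two places, so no single step links them. In a functional assay on MCF7 cells (Homo sapiens) for cytotoxicity, read by MTT assay, with a stated time of 72 h (a lower number here means a stronger inhibitor, a higher number a weaker inhibitor), compound 1 gives 900 nM. In this assay compound 2 gives 8800 nM, the higher of the two numbers, and the gap to compound 1 lies beyond the scatter. Compound 3 `N/C(=N\NC(=S)N1CCSCC1)c1ccc(F)cn1` keeps the thiomorpholine of compound 2 and carries one change: fluoro in place of hydrogen on an aromatic carbon. Within the data shown here, no measured pair isolates this change, since compound 1 also differs in the ring on the thiourea. The writer therefore expects a moderate step downward, not a large one. The expected step of a 2.2-fold lower number from compound 2 to compound 3 (0.34 log units; beyond the scatter) rests on the lower number of compound 1 900 nM, which carries the same fluoro. Compound 3 is estimated at 4000 nM, within 1500 nM to 12000 nM.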

Compound 3, half-maximal inhibitory concentration: 21400 nM
Compound 3: middle estimate off by 5.4-fold (0.73 log units), on the low side; measured number above the stated range.
By their numbers in this assay, from the lowest: compound 1; then compound 2; then compound 3.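

In this assay fluoro in place of hydrogen, two atoms from the ring nitrogen, brings a 2.4-fold higher number from compound 2 to compound 3 (0.39 log units; beyond the scatter) and so is a modest upward step when thiomorpholin-4-yl sits on the thiocarbonyl carbon. With the fluoro held in place, thiomorpholin-4-yl in place of pyrrolidin-1-yl brings a 24-fold higher number from compound 1 to compound 3 (1.38 log units; beyond the scatter) and is the large step of the two. The low number of compound 1 therefore goes with its pyrrolidin-1-yl group and cannot be credited to the fluoro.

The compounds shown leave open whether fluoro moves the number the same way when pyrrolidin-1-yl sits on the thiocarbonyl carbon. They also leave open how chloro, methoxy or an amine would read at the same aromatic carbon, and how piperidine or morpholine would read on the thiocarbonyl carbon. No measurement is at hand that explains either step.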